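A few compounds are considered here, and "the series" means these few. Any claim that something is new, unique, unknown or untested is made for them only; others in the source may bear on it.

Series notes on the cyclohexane carboxamide pair of cores.

Compound 1 `CC(=O)N[C@@H]1CCC[C@H](C(=O)Nc2cc(-c3cnn4c3CCCC4)c(F)cn2)C1` in an ADME assay on cells (Hepatocyte, Rattus norvegicus) for metabolic stability, using equilibrium dialysis (on this read-out lower numbers stand for slow clearance and higher numbers for fast clearance), gives 73 uL/min. Compound 2 `CC(=O)N[C@@H]1CCC[C@H](C(=O)Nc2cc(-c3cnn4c3CCCC4)c(Cl)cn2)C1` in this assay gives 46 uL/min; the two differ by chloro in place of fluoro on an aromatic carbon, and the step is a 1.6-fold lower number from compound 1 to compound 2 (0.20 log units; within the scatter). Compound 3 `CC(=O)N[C@@H]1CCC[C@H](C(=O)Nc2cc(-c3cnn4c3CC(C)(C)C4)c(F)cn2)C1` carries the other core; the two cores differ by a group of 10 heavy atoms (8 carbon, 2 nitrogen; one five-membered non-aromatic ring with 1 hetero atom, one five-membered aromatic ring with 2 hetero atoms) in place of a group of 9 heavy atoms (7 carbon, 2 nitrogen; one five-membered aromatic ring with 2 hetero atoms, one six-membered non-aromatic ring with 1 hetero atom), on an aromatic carbon. Compound 3 in this assay gives 81 uL/min, a step of a 1.1-fold higher number from compound 1 to compound 3 (0.05 log units; within the scatter).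

Compound 4 `CC(=O)N[C@@H]1CCC[C@H](C(=O)Nc2cc(-c3cnn4c3CC(C)(C)C4)c(Cl)cn2)C1` is not yet measured in this assay. It differs from compound 3 by chloro in place of fluoro on an aromatic carbon, the same kind of change as that from compound 1 to compound 2, made twice within the set. The surroundings are described differently: in the earlier change the place is ortho to a group of 9 heavy atoms, in the new change ortho to a large group.

The expected step is a 1.5-fold lower number from compound 3 to compound 4 (0.17 log units; within the scatter), set beside a 1.6-fold lower number from compound 1 to compound 2 (0.20 log units; within the scatter); it rests on that single measured instance, which lies within the scatter, so a step near zero is as plausible as a repeat of it. Compound 4 is estimated at 55 uL/min in this assay, expected to fall between 30 uL/min and 95 uL/min.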

Compound 4, intrinsic clearance in a liver preparation (reported as CLH), per the amount of preparation that the assay uses: 73 uL/min
For compound 4 the middle estimate is 1.3-fold (0.12 log units) below the measured one; low and high end bracket the measured number.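

On the core of compound 3, chloro in place of fluoro gives a 1.1-fold lower number from compound 3 to compound 4 (0.05 log units; within the scatter) in this assay, and with chloro in place, the change of core gives a 1.6-fold higher number from compound 2 to compound 4 (0.20 log units; within the scatter). The halogen change shows no difference that can be told apart between the two cores: the same change on two cores in this assay, a 1.6-fold lower number (0.20 log units; within the scatter) from compound 1 to compound 2 and a 1.1-fold lower number (0.05 log units; within the scatter) from compound 3 to compound 4, 1.4-fold (0.16 log units) apart, within the scatter of two such steps

Every step here lies within the scatter, so the pairs show only that neither change stands out from repeat measurement on either partner; they do not show that a real effect of fixed size carries from one core to the other, and the change of core reads the same way: the same change on two cores in this assay, a 1.1-fold higher number (0.05 log units; within the scatter) from compound 1 to compound 3 and a 1.6-fold higher number (0.20 log units; within the scatter) from compound 2 to compound 4, 1.4-fold (0.16 log units) apart, within the scatter of two such steps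

Open, going by these compounds, is whether a group other than the two halogens at this place on the six-membered aromatic ring, such as methyl, methoxy or a nitrile, would give a step beyond the scatter on either core. Also open, on these data alone, is whether an amine or a carboxylic acid on the cyclohexane would do so.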